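A Single Fluoro Swap on a Weak Inhibitor

The source may hold more compounds than are shown below. What is called first, only, known or untested is meant among the compounds shown, and "the series" means these compounds.

In a functional assay on U-373MG ATCC cells (Homo sapiens) for inhibition, read by colorimetric assay and MTT assay, with a stated time of 72 h (a higher number here means a weaker inhibitor, a lower number a stronger inhibitor), compound 2 (`C=CCCCCOc1ccccc1-c1cnc(OCCC=C)n1C`) gives 33000 nM as the lower of the two numbers available. Compound 1 (`Cn1c2cnc1OCCCCCCCCOc1ccc(F)cc1-2`) gives 73000 nM and so stands higher, by more than the usual scatter. Compound 3 (`COc1ccc(C)cc1-c1cnc(OCCCCc2ccccc2)n1C`) has no number, only the entry "not determined" (no result reported) in its place. Compound 4 (`C=CCCCCOc1ccc(F)cc1-c1cnc(OCCC=C)n1C`) differs from compound 2 in one place (fluoro in place of hydrogen on an aromatic carbon): fluoro in place of hydrogen on an aromatic carbon. Going by the values given here, no measured pair shows this change alone, so the evidence is thin. The expected step (a 1.1-fold higher number from compound 2 to compound 4 (0.04 log units; within the scatter)) stays within the scatter, with no clear direction. In this assay compound 4 is estimated at 36000 nM and expected to fall from 15000 nM to 85000 nM on repeated measurement.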

Compound 4, half-maximal inhibitory concentration: 73000 nM
Estimate against measurement, compound 4: 2.0-fold (0.31 log units) below; the measured number falls inside the stated range.
By their numbers in this assay, from the lowest: compound 2; then compounds 1 and 4 (each within the scatter of the next).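

In this assay, putting fluoro in place of hydrogen on this aromatic carbon, para to a (hex-5-en-1-yl)oxy group, gives a 2.2-fold higher number from compound 2 to compound 4 (0.34 log units; beyond the scatter) and so weakens inhibition modestly. Going by these compounds alone, this is the first measured pair to isolate the change, and it shows that this position is not indifferent to it, though a single pair sets no rule. Nothing measured here explains why the number rises.

Going by these compounds, whether chlorine, a methoxy group or an amine at the same carbon would raise or lower the number remains open. Also open, on these data alone, is whether fluoro has the same effect at other carbons of this ring.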